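The compounds below may be only part of what the source reports. "The series", "measured", "known", "first", "only" and "open" are said of these compounds alone.

Measured compounds:
compound 1 `CC(C)(Oc1ccccc1)C1OCC(C/C=C\CCC(=O)O)C(c2cccnc2)O1` with 75000 nM
compound 2 `COc1ccc(OC(C)(C)C2OCC(C/C=C\CCC(=O)O)C(c3cccnc3)O2)cc1` with > 100000 nM
compound 3 `CC(C)(Oc1ccccc1Br)C1OCC(C/C=C\CCC(=O)O)C(c2cccnc2)O1` with 7000 nM

In an assay for inhibition of prostacyclin synthase (Homo sapiens), using microsomes (a lower number here means a stronger inhibitor, a higher number a weaker inhibitor), compound 3 gives the lowest of the two numbers shown; the nearest is compound 1, and the step of an 11-fold lower number from compound 1 to compound 3 (1.03 log units; beyond the scatter) is large. For compound 2 the value > 100000 nM is a limit of this assay, not a number (the limit of > 100000 nM in this assay, at which 1 of the 3 values shown sits). The step of an at least 14-fold lower number from compound 2 to compound 3 (1.15 log units; beyond the scatter) is therefore also only a floor.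

Compound 4 `CC(C)(Cc1ccc(F)cc1C#N)C1OCC(C/C=C\CCC(=O)O)C(c2cccnc2)O1` differs from compound 3 in one place: a group of 10 heavy atoms (8 carbon, 1 nitrogen, 1 fluorine; one six-membered aromatic ring of carbon only) in place of a group of 8 heavy atoms (6 carbon, 1 oxygen, 1 bromine; one six-membered aromatic ring of carbon only), on a saturated chain carbon bound to two saturated chain carbons and a saturated ring carbon. Among the measured compounds shown here, no measured step has the same change. What bears on it is that compound 1 bears a bare phenyl ring, and that the bromo in compound 3 brought the large step of an 11-fold lower number from compound 1 to compound 3 (1.03 log units; beyond the scatter), whereas the methoxy in compound 2 brought an at least 1.3-fold higher number from compound 1 to compound 2 (0.12 log units; that floor lies within the scatter), within the scatter. The entering group again carries a ring with substituents, but without the bromine or the ether oxygen, so the step is expected to be small, in either direction. Compound 4 is therefore expected to give 8000 nM, between 2000 nM and 30000 nM, a step of a 1.1-fold higher number from compound 3 to compound 4 (0.06 log units; within the scatter).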

Compound 4, half-maximal inhibitory concentration: 7000 nM
Estimate against measurement, compound 4: 1.1-fold (0.06 log units) above, within the range that was stated.
By their numbers in this assay, from the lowest: compounds 3 and 4 (each within the scatter of the next); then compound 1. At a limit, above all of these: compound 2.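

In this assay, the step of no change at the digits printed from compound 3 to compound 4 (within the scatter) shows that, on this saturated chain carbon, the 2-bromophenoxy group can give way to a ring group with neither bromine nor ether oxygen and the number holds. Among the compounds shown here, the step of an 11-fold lower number from compound 1 to compound 4 (1.03 log units; beyond the scatter) then shows that bromine is not the only change that moves the number away from that of compound 1, as a ring carrying nitrile and fluorine does so too. Compound 2 stands at a limit, not a number, so the step of an at least 14-fold lower number from compound 2 to compound 4 (1.15 log units; beyond the scatter) is only a floor: the limit of > 100000 nM in this assay, at which 1 of the 4 values shown sits.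

The compounds shown leave open which part of the entering group matters, as the nitrile, the fluorine and the loss of the ether oxygen all arrive together. They also leave open whether an amine or a longer chain on this carbon would give a lower number.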